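The compounds below may be only part of what the source reports. "The series", "measured", "known", "first", "only" and "open" are said of these compounds alone.

Series notes, a functional assay on A549 cells (Homo sapiens) for inhibition; a higher number here means a weaker inhibitor, a lower number a stronger inhibitor.

compound 1, `CCOC(=O)c1ccc(NC(=O)N2CC2C#N)cc1`: 2900 nM
compound 2, `CCCCNC(=O)N1CC1C#N`: 18000 nM
compound 3, `N#CC1CN1C(=O)Nc1ccccc1`: 9000 nM

Compound 2 carries the highest number of the three; compound 3 sits within the scatter of it, while compound 1 lies well below it, beyond the scatter. Compound 4 `N#CC1CN1C(N)=O` is not yet measured. It differs from compound 2 by hydrogen in place of butyl on an amide-type nitrogen. Going by the values given here, the only single-place step measured so far, a 3.1-fold higher number from compound 1 to compound 3 (0.49 log units; beyond the scatter), concerns an aromatic carbon rather than the amide-type nitrogen, so it gives no direct guide here; the values of compound 2 and compound 3 show only that two different substituents on that nitrogen land within the scatter of each other. Stripping the butyl away altogether is expected to shift compound 4 by a 1.9-fold higher number from compound 2 to compound 4 (0.29 log units; within the scatter), toward a higher number. Compound 4 is estimated at 35000 nM, with a range from 12000 nM to 100000 nM.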

Compound 4, half-maximal inhibitory concentration: > 280000 nM
Compound 4: a limit, no number; the forecaster's own chance of this, stated with the estimate: 30%; at least 8.0-fold (0.90 log units) between middle value and limit.
By their numbers in this assay, from the lowest: compound 1; then compounds 3 and 2 (each within the scatter of the next). At a limit, above all of these: compound 4.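

Hydrogen in place of butyl on the amide-type nitrogen gives an at least 15-fold higher number from compound 2 to compound 4 (1.19 log units; beyond the scatter), the first step read at this position, and it is large. Compound 4 stands at a limit, not at a number: the limit of > 280000 nM in this assay, at which 1 of the 4 values shown sits. Among the compounds shown, a measured value in this assay thus goes with a substituent on this nitrogen, whether butyl in compound 2 or phenyl in compound 3.

Going by these compounds, how far compound 4 really lies beyond its limit stays open. Also open, on these data alone, is what a small methyl or a longer chain such as octyl would give on this nitrogen.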